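The source may hold more compounds than are shown below. What is called first, only, known or untested is meant among the compounds shown, and "the series" means these compounds.

In a functional assay on MKN-74 cells (Homo sapiens) for antiproliferative activity, with a stated time of 24 h (on this read-out higher numbers stand for weaker inhibition and lower numbers for stronger inhibition), compound 1 `Cc1ccccc1NC(=S)N1CCc2c(sc(NC(=O)c3ccccc3Cl)c2C(N)=O)C1` gives 11700 nM. In this assay, for the measured compounds named here, compound 2 `NC(=O)c1c(NC(=O)c2ccccc2Br)sc2c1CCN(C(=S)Nc1ccccc1C(F)(F)F)C2` gives 24300 nM, the higher of the two numbers so far; its only neighbour is compound 1, whose number lies lower by a margin beyond the scatter. Compound 1 and compound 2 differ in two places at once, on the thiourea side and on the amide side, so their two values show only what both changes together do and not what either does alone.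

Compound 3 `Cc1ccccc1NC(=S)N1CCc2c(sc(NC(=O)c3ccccc3Br)c2C(N)=O)C1` has not yet been measured. It differs from compound 2 by methyl in place of trifluoromethyl on an aromatic carbon, so that it carries the thiourea-side aryl group of compound 1 together with the amide-side acyl group of compound 2. Because compound 1 gives 11700 nM with that same methyl in place, a step downward of modest size is expected from compound 2 to compound 3, a 1.6-fold lower number from compound 2 to compound 3 (0.21 log units; within the scatter), though it may not clear the scatter. Compound 3 is estimated at 15000 nM, within a range from 6000 nM to 38000 nM.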

Compound 3, half-maximal inhibitory concentration: > 50000 nM
Compound 3: a limit, no number (the forecaster's own chance of this, stated with the estimate: 5%); at least 3.3-fold (0.52 log units) between middle value and limit.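

In this assay compound 3 stands at a limit of the assay and not at a number: the limit of > 50000 nM in this assay, at which 1 of the 3 values shown sits.

With the bromo-bearing amide side held fixed, methyl in place of trifluoromethyl gives an at least 2.0-fold higher number from compound 2 to compound 3 (0.31 log units; beyond the scatter), and with the methyl-bearing thiourea side held fixed, bromo in place of chloro gives an at least 4.2-fold higher number from compound 1 to compound 3 (0.63 log units; beyond the scatter). Each of the two changes that were tangled together in compound 1 and compound 2 can thus now be read alone, and in these two single steps both trifluoromethyl over methyl and chloro over bromo go with the lower number, so the lower number of compound 1 goes with its chloro and not with its methyl.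

The compounds shown leave open how far either step carries over to the other side of the molecule, since the pairing of chloro with trifluoromethyl is not among them, and the limit leaves the true size of both steps unknown. They also leave open what other groups on the aromatic carbon would do, such as an amine, a carboxylic acid or a nitrile in place of the trifluoromethyl.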